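A few compounds are considered here, and "the series" means these few. Any claim that something is new, unique, unknown or untested is made for them only; others in the source may bear on it.

In a functional assay on the whole organism (spleen, spleen, strain LEW) for inhibition, with Rattus norvegicus as the target, with a stated time of 4 days, at a dose of 1 mg/kg by the oral route (on this read-out lower numbers stand for less inhibition and higher numbers for more inhibition at the one dose given (going by the name of the read-out)), compound 1 `CCc1cc(CN2CC(C(=O)O)C2)sc1-c1noc(-c2ccc(Oc3ccccc3OC)cc2)n1` gives 74%. Compound 2 `CCc1ccccc1Oc1ccc(-c2nc(-c3sc(CN4CC(C(=O)O)C4)cc3CC)no2)cc1`, with ethyl in place of methoxy on an aromatic carbon, gives 62% in this assay, and compound 3 `CCCc1ccccc1Oc1ccc(-c2nc(-c3sc(CN4CC(C(=O)O)C4)cc3CC)no2)cc1`, with propyl in place of methoxy on an aromatic carbon, gives 56%. Compound 3 thus stands at the lower end of the three numbers: the step of a number 18 percentage points lower from compound 1 to compound 3 (beyond the scatter) lies beyond the scatter, whereas the step of a number 6 percentage points lower from compound 2 to compound 3 (within the scatter) lies within it.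

Compound 4 `CCCCc1ccccc1Oc1ccc(-c2nc(-c3sc(CN4CC(C(=O)O)C4)cc3CC)no2)cc1` lengthens the chain by one more carbon: methyl in place of hydrogen on a saturated chain carbon, three bonds along the chain from an aromatic carbon. The measured step that bears most directly on this change is a number 6 percentage points lower from compound 2 to compound 3 (within the scatter), a change within the scatter. The larger steps of a number 12 percentage points lower from compound 1 to compound 2 (beyond the scatter) and a number 18 percentage points lower from compound 1 to compound 3 (beyond the scatter) concern the replacement of methoxy by an alkyl chain rather than a further lengthening of that chain, so they speak only indirectly to compound 4. On this basis the step of a number 6 percentage points lower from compound 3 to compound 4 (within the scatter) in this assay is expected to be small, at most a slight lowering, and not clearly beyond the scatter. Compound 4 is therefore estimated to give 50% in this assay, with a range from 36% to 64%.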

Compound 4, a percentage reported as inhibition, in the whole organism at one dose (the size of the read-out at that dose, not a potency): 66%
For compound 4 the middle estimate is 16 percentage points below the measured one, and the stated range ends below it.
By their numbers in this assay, from the lowest: compounds 3, 2, 4 and 1 (each within the scatter of the next, the first and the last beyond it).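

In this assay the further extension from propyl to butyl gives a number 10 percentage points higher from compound 3 to compound 4 (within the scatter) and the extension from ethyl to butyl gives a number 4 percentage points higher from compound 2 to compound 4 (within the scatter) so that ethyl, propyl and butyl at this place are not told apart, and chain length shows no clear trend across these compounds. The butyl chain also differs from the earlier alkyl chains in its comparison with methoxy: butyl in place of methoxy gives a number 8 percentage points lower from compound 1 to compound 4 (within the scatter) whereas the steps to ethyl and to propyl were printed as beyond the scatter, so replacing methoxy with an alkyl chain does not give a separation from compound 1 for every chain length. No available evidence bears on the reason for this result.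

The compounds shown leave open whether a longer chain such as pentyl or hexyl, or a branched chain such as isopropyl or tert-butyl, would stand apart from the straight chains at this place. They also leave open how a halogen such as chlorine or a larger alkoxy group such as ethoxy would compare with methoxy on the same aromatic carbon.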